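Acetylation of the free hydroxyl in a sesquiterpene ester series

The source may hold more compounds than are shown below. What is called first, only, known or untested is meant among the compounds shown, and "the series" means these compounds.

Measured compounds and values:
- compound 1 `COc1ccc(C(=O)O[C@H]2C=C(C)C(=O)C[C@@]3(C)CC[C@@](O)(C(C)C)[C@H]23)cc1`: 38900 nM
- compound 2 `COc1ccc(C(=O)O[C@H]2CC(C)=C[C@H](O)[C@@]3(C)[C@@H](OC(C)=O)C[C@@](O)(C(C)C)[C@H]23)cc1`: 23000 nM
- compound 3 `COc1ccc(C(=O)OCC2=CC[C@@]3(C)CC[C@]4(C(C)C)O[C@]34CC2)cc1`: > 100000 nM

All three carry the same methoxybenzoate ester on a closely related bicyclic core. In a functional assay on HL-60 cells (Homo sapiens) for cytotoxicity, read by MTT assay, with a stated time of 72 h (a lower number here means a stronger inhibitor, a higher number a weaker inhibitor), compound 2 gives 23000 nM, the lowest of the two numbers recorded. Compound 1, the nearest, gives 38900 nM, a difference that falls within the scatter of the method, so the two cannot be ordered. For compound 3 the value > 100000 nM is a limit of the assay rather than a number (the limit of > 100000 nM in this assay, at which 1 of the 3 values shown sits).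

The unmeasured compound 4 `COc1ccc(C(=O)O[C@H]2CC(C)=C[C@H](OC(C)=O)[C@@]3(C)[C@@H](OC(C)=O)C[C@@](O)(C(C)C)[C@H]23)cc1` follows from compound 2 by one change:
acetyl in place of hydrogen on an oxygen on a saturated carbon
Compound 2 already carries one acetate on the core, and compound 4 adds a second in place of the remaining hydroxyl. Going by the values given here, no measured pair in the set shows this change by itself, so there is no step on which to lean. With the two numbers so close and one value only a limit, the expected step is none beyond the scatter, a 1.1-fold higher number from compound 2 to compound 4 (0.04 log units; within the scatter) in this assay. Compound 4 is estimated at 25000 nM, within 8000 nM to 80000 nM.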

Compound 4, half-maximal inhibitory concentration: 11300 nM
Compound 4: the middle estimate sits 2.2-fold (0.34 log units) above what was measured, and the stated range covers the measured number.
By their numbers in this assay, from the lowest: compound 4; then compounds 2 and 1 (each within the scatter of the next). At a limit, above all of these: compound 3.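

In this assay, going by these compounds alone, acetyl in place of hydrogen on an oxygen on a saturated carbon gives a 2.0-fold lower number from compound 2 to compound 4 (0.31 log units; beyond the scatter), a modest change and the only step that can be read. A free hydroxy at this position is therefore not needed for the cytotoxic read-out, as the acetoxy compound 4 keeps a measurable value and does not lose ground against compound 2. Nothing in the data accounts for the size or direction of this step.

Going by these compounds, whether a longer acyl chain such as butanoyl, or an acyl group carrying an amine, would move the number further at this oxygen stays open. On these data alone, the contribution of the other acetate on the shared core also stays open.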